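A Halogen Swap at the Assay Limit

The source may hold more compounds than are shown below. What is called first, only, known or untested is meant among the compounds shown, and "the series" means these compounds.

In an ADME assay on MDBK cells (Bos taurus) for cytotoxicity, read by MTT assay, with a stated time of 96 h (a higher number here means that more compound is tolerated, a lower number that less compound is tolerated), compound 1 (`Clc1cccc(/N=N/N2CCCCC2)c1`) gives > 100000 nM, which is a limit of the assay and not a number. Compound 2 (`CN(C)CCCNc1ccc(/N=N/c2ccccc2)cc1`) gives 58000 nM. Compound 3 (`CN(C)CCCN(/N=N/c1ccccc1)c1cccc(C(F)(F)F)c1`) gives 38000 nM. Among these three, only compound 1 stands at the limit, while the other two give numbers. Compound 4 (`Brc1cccc(/N=N/N2CCCCC2)c1`) carries bromo in place of chloro on an aromatic carbon. Within the data shown here, no two measured compounds differ in one place alone, so the data offer no direct guide to this swap. An estimated a number no higher from compound 1 to compound 4 (the limit leaves the size open) is expected in this assay, with no direction favoured and nothing beyond the scatter. Compound 4 is estimated at 100000 nM, with an expected range of 45000 nM to 200000 nM.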

Compound 4, half-maximal cytotoxic concentration: > 100000 nM
Compound 4 was reported as a limit; the forecaster's own chance of this, stated with the estimate: 55%; the middle value lies on the limit itself.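

Among these compounds, compound 1 and compound 4 both stand at a limit of the assay and not at a number, and no step between them can be read. The compounds shown leave open whether bromo in place of chloro shifts the tolerated concentration in this assay at all.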